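The compounds below may be only part of what the source reports. "The series", "measured", "known", "first", "only" and "open" are said of these compounds alone.

Measured compounds and their values in a functional assay on HepG2 cells (Homo sapiens) for antiproliferative activity, read by MTT assay, with a stated time of 72 h; a higher number here means a weaker inhibitor, a lower number a stronger inhibitor:

compound 1, `COc1ncc(-c2ccc3c(c2)NC(=O)CO3)cc1NS(=O)(=O)c1ccc(F)cc1`: 6590 nM
compound 2, `O=C1COc2ccc(-c3cnc4ccccc4c3)cc2N1`: 26300 nM
compound 3, `COc1ncc(-c2ccc3c(c2)N(c2ccc(Cl)cc2)C(=O)CO3)cc1NS(=O)(=O)c1ccc(F)cc1`: 17900 nM

Compound 3 is compound 1 with 4-chlorophenyl in place of hydrogen on an amide-type nitrogen in a ring, and that change produced a 2.7-fold higher number from compound 1 to compound 3 (0.43 log units; beyond the scatter). Compound 2 shares no counted single-point relation with compound 1: the difference between the two cores is not broken down here. Its number lies within the scatter of that of compound 3 and beyond the scatter from that of compound 1.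

Compound 4, `O=C1COc2ccc(-c3cnc4ccccc4c3)cc2N1c1ccc(Cl)cc1`, has not yet been measured in this assay. It stands to compound 2 exactly as compound 3 stands to compound 1: 4-chlorophenyl in place of hydrogen on an amide-type nitrogen in a ring, the same change at the same place. Going by the values given here, only that one earlier step is available to judge it, and it was made on a different core. Compound 4 is therefore expected to show a 2.5-fold higher number from compound 2 to compound 4 (0.39 log units; beyond the scatter), mirroring a 2.7-fold higher number from compound 1 to compound 3 (0.43 log units; beyond the scatter), starting from the point where compound 2 gives 26300 nM. For compound 4 the estimate is 65000 nM, with a likely range from 22000 nM to 200000 nM.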

Compound 4, half-maximal inhibitory concentration: 32700 nM
The estimate for compound 4 lay 2.0-fold (0.30 log units) above the measured number, and the stated range covers the measured number.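

In this assay, 4-chlorophenyl in place of hydrogen on the amide-type nitrogen of the core of compound 2 gave a 1.2-fold higher number from compound 2 to compound 4 (0.09 log units; within the scatter), a step that on its own cannot be told apart from no change. Set beside the step on the other core, the two results do not separate: the same change on two cores in this assay, a 2.7-fold higher number (0.43 log units; beyond the scatter) from compound 1 to compound 3 and a 1.2-fold higher number (0.09 log units; within the scatter) from compound 2 to compound 4, 2.2-fold (0.34 log units) apart, within the scatter of two such steps. Going by these compounds alone, this shows that the change can be carried between these two cores without a detectable difference in its size, but two pairs do not establish a fixed size for it, since only one of the two steps lies beyond the scatter, and they give no reason for either step.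

On the amide-type nitrogen the compounds shown carry only hydrogen or 4-chlorophenyl, so it remains open how a methyl, an unsubstituted phenyl or a longer chain ending in an amine would read on either core. From the compounds shown here alone, whether the same step would hold on a third core also remains open.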